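A few compounds are considered here, and "the series" means these few. Any claim that something is new, unique, unknown or untested is made for them only; others in the source may bear on it.

Measured so far in an ADME assay on HEp-2 cells (Homo sapiens) for cytotoxicity; a higher number here means that more compound is tolerated, a lower number that less compound is tolerated
- compound 1 `O=C(Nc1ccc(Cl)cc1Cl)[C@@H]1CCCN1S(=O)(=O)c1cccc2cccnc12` gives > 50000 nM (a limit of the assay, not a number)
- compound 2 `Cc1ccc(C(F)(F)F)cc1NC(=O)[C@@H]1CCCN1S(=O)(=O)c1cccc2cccnc12` gives 4800 nM

In this assay compound 1 stands only at the limit > 50000 nM and has no number of its own. Compound 2 gives a true reading of 4800 nM.

Compound 3 `Cc1cc(NC(=O)[C@@H]2CCCN2S(=O)(=O)c2cccc3cccnc23)n(C(C)(C)C)n1` keeps the core of compound 1 and carries 3-methyl-1-(tert-butyl)-1H-pyrazol-5-yl in place of 2,4-dichlorophenyl on an amide-type nitrogen. The count reads 3-methyl-1-(tert-butyl)-1H-pyrazol-5-yl in place of 2,4-dichlorophenyl on an amide-type nitrogen for this exchange.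

For the measured compounds named here, no measured step covers this change, so the direction rests on the reading of compound 2 at 4800 nM as the only number available. An estimated at least 2.0-fold lower number from compound 1 to compound 3 (0.30 log units; that floor lies within the scatter) is expected, downward in this assay and loose in size. The expected value for compound 3 is 25000 nM with an estimated range from 6000 nM to 50000 nM as its upper end.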

Compound 3, half-maximal cytotoxic concentration: > 50000 nM
Compound 3 ended at the assay's limit; the forecaster's own chance of this, stated with the estimate: 35%; middle value at least 2.0-fold (0.30 log units) away from the limit.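

In this assay compound 1 and compound 3 both end at a limit of the assay, so no step between them can be read: the limit of > 50000 nM in this assay, at which 2 of the 3 values shown sit.

On these data alone, whether 3-methyl-1-(tert-butyl)-1H-pyrazol-5-yl in place of 2,4-dichlorophenyl moves the half-maximal cytotoxic concentration at all, and in which direction, remains open.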